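Enlarging the ether on the shared core of compound 2

This account rests on a few compounds, and the source may have more. Where it says the series, first, only, none or still open, it means among the compounds named here.

Compound 2 `CC/C=C/C(=O)Nc1cc2c(N3CCCc4ccccc43)ncnc2cc1OC` has been measured in a functional assay on PC-3 cells (Homo sapiens) for antiproliferative activity, read by MTT assay, with a stated time of 72 h (a lower number here means a stronger inhibitor, a higher number a weaker inhibitor), where compound 2 gives 6310 nM, the lowest number of the three in hand, though both others sit within the scatter of it. Compound 3 `COc1cc2ncnc(N3CCCc4ccccc43)c2cc1NC(=O)/C=C/C(C)C` gives 8430 nM, and the step of a 1.3-fold higher number from compound 2 to compound 3 (0.13 log units; within the scatter) stays within the scatter. Compound 1 `CC/C=C/C(=O)Nc1cc2c(N3CCc4ccccc43)ncnc2cc1O[C@@H]1CCOC1` gives 9590 nM. Compound 4 `CC/C=C/C(=O)Nc1cc2c(N3CCCc4ccccc43)ncnc2cc1O[C@@H]1CCOC1` differs from compound 2 by oxolan-3-yl in place of methyl on an oxygen on an aromatic ring. Going by the values given here, no measured step bears directly on this change; compound 1 carries the same ether but differs from compound 4 elsewhere, so its value shows only that such a group sits near the number of compound 2. A step of a 1.2-fold higher number from compound 2 to compound 4 (0.08 log units; within the scatter) is therefore expected, not beyond the scatter in this assay. For compound 4 the estimate is 7500 nM, with a range from 3000 nM to 20000 nM.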

Compound 4, half-maximal inhibitory concentration: 14300 nM
Compound 4: middle estimate off by 1.9-fold (0.28 log units), on the low side; measured number inside the range.
By their numbers in this assay, from the lowest: compounds 2, 3, 1 and 4 (each within the scatter of the next, the first and the last beyond it).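

In this assay, going by these compounds alone, oxolan-3-yl in place of methyl on an oxygen on an aromatic ring now has a direct reading, a 2.3-fold higher number from compound 2 to compound 4 (0.36 log units; beyond the scatter), the only modest step so far to pass beyond the scatter. With that ether held constant, 1,2,3,4-tetrahydroquinolin-1-yl in place of 2,3-dihydro-1H-indol-1-yl gives a 1.5-fold higher number from compound 1 to compound 4 (0.17 log units; within the scatter), so these two groups are not told apart here. Nothing measured accounts for the ether step. Open, going by these compounds, is whether ethoxy or an ether chain ending in an amine would stay near compound 2, and whether the opposite stereoisomer of the oxolan-3-yl group would match compound 4.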